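A few compounds are considered here, and "the series" means these few. Any claim that something is new, unique, unknown or untested is made for them only; others in the source may bear on it.

Values so far in a functional assay on COLO 205 cells (Homo sapiens) for inhibition, read by sulforhodamine B assay, with a stated time of 48 h, tested at 50 uM; on this read-out lower numbers stand for less inhibition of growth and higher numbers for more inhibition of growth at the one concentration tested:

- compound 1 `COc1cc(/C=C/C(=O)/C=C/c2ccco2)ccc1OCc1cn(CCCOc2cc(=O)oc3ccccc23)nn1` gives 59%
- compound 2 `COc1ccccc1/C=C/C(=O)/C=C/c1ccc(OCc2cn(CCCOc3cc(=O)oc4ccccc34)nn2)c(OC)c1` gives 57%
- compound 3 `COc1cc(/C=C/C(=O)/C=C/c2cccs2)ccc1OCc1cn(CCCCCOc2cc(=O)oc3ccccc23)nn1` gives 30%

Compound 2 lies within the scatter of compound 1 and well beyond the scatter above compound 3 . Among the measured compounds shown here, compound 3 differs from compound 2 in more than one place, so it offers no clean step for this comparison.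

Next is compound 4 `COc1ccc(/C=C/C(=O)/C=C/c2ccc(OCc3cn(CCCOc4cc(=O)oc5ccccc45)nn3)c(OC)c2)cc1OC`, which carries 3,4-dimethoxyphenyl in place of 2-methoxyphenyl on a double-bonded chain carbon bound to a double-bonded chain carbon.

For the measured compounds named here, only one measured step bears on this place: a number 2 percentage points lower from compound 1 to compound 2 (within the scatter). That exchange of furan-2-yl for 2-methoxyphenyl left the reading within the scatter. It is a single step with a different group, so it is only weak support. No step beyond the scatter is expected in this assay, and no direction is favoured with any confidence. The estimated outcome is a number 2 percentage points lower from compound 2 to compound 4 (within the scatter). For compound 4 the expected value is 55%, with an estimated range of 40% to 69%.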

Compound 4, percent growth inhibition at one concentration: 65%
Compound 4: the middle estimate sits 10 percentage points below what was measured; the measured number falls inside the stated range.
By their numbers in this assay, from the lowest: compound 3; then compounds 2, 1 and 4 (each within the scatter of the next).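

In this assay, 3,4-dimethoxyphenyl on a double-bonded chain carbon bound to a double-bonded chain carbon reads alike with 2-methoxyphenyl, with a number 8 percentage points higher from compound 2 to compound 4 (within the scatter), and with furan-2-yl, with a number 6 percentage points higher from compound 1 to compound 4 (within the scatter). Three different groups have now been seen at this place without a step beyond the scatter, and the additional methoxy group of the 3,4-dimethoxyphenyl compound brings none either. No measurement on hand bears on why these readings stay together.

From the compounds shown here alone, whether a group carrying an amine or a carboxylic acid at this place would also stay within the scatter remains open. Compound 3 differs from these compounds in more than one place, so the contribution of its longer chain cannot be separated from that of its other group.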